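The source may report more compounds than this note shows. Statements on the series, on what has been measured and on what is new or still open speak of the compounds shown alone.

Of the compounds shown here, two of a shared core have been measured in an assay on isolated protein for binding affinity to stress-70 protein, mitochondrial (Homo sapiens); a lower number here means tighter binding, a higher number weaker binding. Compound 1 `CN1c2ccc(NC(=O)Nc3ccc([N+](=O)[O-])cc3)cc2C(C)(C)C(=O)C1(C)C` gives 300 nM in this assay, the lowest of the two numbers. Compound 2 `CN1c2ccc(NC(=S)Nc3ccc([N+](=O)[O-])cc3)cc2C(C)(C)C(=O)C1(C)C` gives 1100 nM in this assay, a weaker figure than compound 1 shows, and the gap lies beyond the usual scatter. Compound 3 `CN1c2ccc(NC(=O)Nc3ccc(C(F)(F)F)cc3)cc2C(C)(C)C(=O)C1(C)C` is not yet measured; it differs from compound 1 in one place: trifluoromethyl in place of nitro on an aromatic carbon. Going by the values given here, no measured pair shows this change, so its size in this assay is unknown. A small step, near the scatter or slightly weakening, is expected from compound 1 to compound 3, namely a 1.5-fold higher number from compound 1 to compound 3 (0.18 log units; within the scatter). For compound 3, the estimate is 450 nM, within 150 nM to 1500 nM.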

Compound 3, dissociation constant: 1500 nM
Compound 3: middle estimate off by 3.3-fold (0.52 log units), on the low side; low and high end bracket the measured number.
By their numbers in this assay, from the lowest: compound 1; then compounds 2 and 3 (each within the scatter of the next).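

In this assay, replacing the 4-nitrophenyl with 4-(trifluoromethyl)phenyl gives a 5.0-fold higher number from compound 1 to compound 3 (0.70 log units; beyond the scatter). This position on the aromatic ring therefore affects binding, and trifluoromethyl is not an even swap for nitro here. The data give no measured reason for this loss.

From the compounds shown here alone, whether a nitrile, an amine or a carboxylic acid at this position would bind as well as the nitro group remains open. So does whether the same change would have a similar effect on compound 2.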